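The source may report more compounds than this note shows. Statements on the series, on what has been measured and on what is new or still open speak of the compounds shown alone.

Measured in a functional assay (mast cells) for inhibition, with Rattus norvegicus as the target; a higher number here means that more compound is needed for the effect, a lower number that less compound is needed:
- compound 1 `COc1ccc(N/N=C2\CCC(C)n3c2ncc(C(=O)O)c3=O)cc1`: 128000 nM
- compound 2 `CCOc1ccc(N/N=C2\CCC(C)n3c2ncc(C(=O)O)c3=O)cc1`: 17600 nM
- compound 3 `CC1CC/C(=N\Nc2ccc(C(F)(F)F)cc2)c2ncc(C(=O)O)c(=O)n21`: 280 nM

Of these three, compound 3 has the lowest number, at 280 nM. Its distance from the other two is given by a 63-fold lower number from compound 2 to compound 3 (1.80 log units; beyond the scatter) and a 460-fold lower number from compound 1 to compound 3 (2.66 log units; beyond the scatter), both large.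

The next step leads to compound 4 `CCCCc1ccc(N/N=C2\CCC(C)n3c2ncc(C(=O)O)c3=O)cc1`, which has butyl in place of trifluoromethyl on an aromatic carbon, para to a large group: butyl in place of trifluoromethyl on an aromatic carbon.

For the measured compounds named here, no measured compound carries butyl, so no measured step matches this change directly. Two kinds of step bear on it. The large steps into compound 3 show how far the number falls when trifluoromethyl replaces either alkoxy group, so removing trifluoromethyl may well raise it. The single chain extension, a 7.3-fold lower number from compound 1 to compound 2 (0.86 log units; beyond the scatter), is modest and points the other way, suggesting that the longer butyl chain could recover part of that rise. Going by the values given here, it is only one pair, so it is weak evidence.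

A modest to large rise in this assay is therefore expected, smaller than the step from the alkoxy compounds. The expected change is a 6.4-fold higher number from compound 3 to compound 4 (0.81 log units; beyond the scatter). Compound 4 is estimated at 1800 nM, with an expected range of 250 nM to 13000 nM.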

Compound 4, half-maximal effective concentration: 1700 nM
Estimate against measurement, compound 4: 1.1-fold (0.02 log units) above, within the range that was stated.
By their numbers in this assay, from the lowest: compound 3; then compound 4; then compound 2; then compound 1.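

Notes on the group para to a large group: in this assay, an all-carbon chain gives a lower number than either alkoxy group, with a 10-fold lower number from compound 2 to compound 4 (1.02 log units; beyond the scatter) and a 75-fold lower number from compound 1 to compound 4 (1.88 log units; beyond the scatter), so the two compounds without an oxygen on this aromatic carbon both sit below the two that have one. Butyl and trifluoromethyl have the same heavy-atom count and neither has a hydrogen-bond donor or acceptor, yet a 6.1-fold higher number from compound 3 to compound 4 (0.78 log units; beyond the scatter), so those counts alone do not set the number at this position. Nothing available explains why these groups differ in this way.

Still open, from the compounds shown here alone, is whether a longer chain such as hexyl, or a branched one such as tert-butyl, would move the number further from that of compound 4, since only one plain alkyl chain appears here. Also unresolved is whether a chlorine or a nitrile on the same aromatic carbon would reach the level of compound 3, and whether the order of these four groups would hold with a different group in place of the carboxylic acid on the shared core.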